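From Difluorophenyl to Bromophenyl at an Aromatic Ether

The source may hold more compounds than are shown below. What is called first, only, known or untested is meant among the compounds shown, and "the series" means these compounds.

Three compounds share one core and differ only in the aryl group on an oxygen on an aromatic ring. Compound 1 `Cc1nn(C)c(Oc2ccccc2F)c1/C=N\CCCCCCOc1cc2oc(=O)cc(C)c2cc1Cl` carries 2-fluorophenyl, compound 2 `Cc1nn(C)c(Oc2cccc(F)c2F)c1/C=N\CCCCCCOc1cc2oc(=O)cc(C)c2cc1Cl` 2,3-difluorophenyl, and compound 3 `Cc1nn(C)c(Oc2ccc(F)c(F)c2)c1/C=N\CCCCCCOc1cc2oc(=O)cc(C)c2cc1Cl` 3,4-difluorophenyl. In a functional assay on U-87MG ATCC cells for antiproliferative activity against U-87 MG (Homo sapiens), read by MTT assay, with a stated time of 72 h (a lower number here means a stronger inhibitor, a higher number a weaker inhibitor), compound 1 gives > 25000 nM, a limit of the assay rather than a number. Compound 2 likewise gives > 25000 nM, a limit. Compound 3 gives > 25000 nM, also a limit. The steps a step that the two limits leave unreadable from compound 1 to compound 2, a step that the two limits leave unreadable from compound 1 to compound 3 and a step that the two limits leave unreadable from compound 2 to compound 3 are therefore unreadable, since every value sits at the limit of > 25000 nM in this assay, at which 3 of the 3 values shown sit. Compound 4 `Cc1nn(C)c(Oc2ccccc2Br)c1/C=N\CCCCCCOc1cc2oc(=O)cc(C)c2cc1Cl` differs from compound 3 by 2-bromophenyl in place of 3,4-difluorophenyl on an oxygen on an aromatic ring. No readable step bears on this change, so compound 4 is expected to stay at the limit as well, with an expected step that the limit leaves unreadable from compound 3 to compound 4 of essentially none. Compound 4 is estimated at 30000 nM, ranging from 8000 nM to 100000 nM.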

Compound 4, half-maximal inhibitory concentration: 21800 nM
Beside the measured number, compound 4's estimate is 1.4-fold (0.14 log units) above it, within the range that was stated.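

With 2-bromophenyl on this oxygen, compound 4 in this assay gives a number rather than a limit, so this position can yield a measurable value: the limit of > 25000 nM in this assay, at which 3 of the 4 values shown sit.

Set against the two difluorophenyl groups, the change gives an at least 1.1-fold lower number from compound 3 to compound 4 (0.05 log units; that floor lies within the scatter) and an at least 1.1-fold lower number from compound 2 to compound 4 (0.05 log units; that floor lies within the scatter). Bromo in place of fluoro gives an at least 1.1-fold lower number from compound 1 to compound 4 (0.05 log units; that floor lies within the scatter), so these floors alone do not establish a real gain.

From the compounds shown here alone, how a plain phenyl, or a phenyl carrying an amine or a carboxylic acid, would behave on this oxygen stays open.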